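Nitrocatechol chalcones: five-membered heteroaryl swap, compound 3

The source may hold more compounds than are shown below. What is called first, only, known or untested is meant among the compounds shown, and "the series" means these compounds.

Measured so far:
compound 1 `O=C(/C=C/c1ccsc1)c1cc(O)c(O)c([N+](=O)[O-])c1` — 42100 nM
compound 2 `O=C(/C=C/c1ccoc1)c1cc(O)c(O)c([N+](=O)[O-])c1` — 71400 nM

In an assay on isolated protein for inhibition of Amine oxidase [flavin-containing] B (Homo sapiens), read by fluorescence (a lower number here means a stronger inhibitor, a higher number a weaker inhibitor), compound 2 gives 71400 nM, and compound 1 gives 42100 nM; the two numbers sit within the usual scatter of each other, as the step of a 1.7-fold higher number from compound 1 to compound 2 (0.23 log units; within the scatter) shows. Compound 3 `O=C(/C=C/c1nccs1)c1cc(O)c(O)c([N+](=O)[O-])c1` differs from compound 2 by 1,3-thiazol-2-yl in place of furan-3-yl on a double-bonded chain carbon bound to a double-bonded chain carbon. For the measured compounds named here, only the step from compound 1 to compound 2 bears on this change, and it stays within the scatter, so no step beyond the scatter is expected in this assay here either; the expected step is a 1.3-fold lower number from compound 2 to compound 3 (0.11 log units; within the scatter). For compound 3 the estimate in this assay is 55000 nM, with a range from 15000 nM to 180000 nM.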

Compound 3, half-maximal inhibitory concentration: 59200 nM
For compound 3 the middle estimate is 1.1-fold (0.03 log units) below the measured one; low and high end bracket the measured number.
By their numbers in this assay, from the lowest: compounds 1, 3 and 2 (each within the scatter of the next).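

In this assay the change from furan-3-yl to 1,3-thiazol-2-yl gives a 1.2-fold lower number from compound 2 to compound 3 (0.08 log units; within the scatter) and the change from thiophen-3-yl to 1,3-thiazol-2-yl gives a 1.4-fold higher number from compound 1 to compound 3 (0.15 log units; within the scatter) on the same double-bonded chain carbon. A five-membered aromatic ring with 2 hetero atoms therefore reads the same here as both rings with 1 hetero atom, which the earlier pair could not show. Nothing available explains this sameness.

Still open, on these data alone, is whether a phenyl ring, a pyridine ring or a methyl group on the 1,3-thiazol-2-yl ring would give a step beyond the scatter at this place. All three numbers remain weak enough that what the shared core contributes cannot be separated from these rings.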